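Methoxy in place of methyl: notes on compound 3

This account rests on a few compounds, and the source may have more. Where it says the series, first, only, none or still open, it means among the compounds named here.

In a functional assay on A549 cells (Homo sapiens) for antiproliferative activity, read by sulforhodamine B assay, with a stated time of 72 h (on this read-out higher numbers stand for weaker inhibition and lower numbers for stronger inhibition), compound 1 `O=C(/C=C/c1csc2ccccc12)c1ccccc1O` gives 5300 nM and compound 2 `Cc1ccc(O)c(C(=O)/C=C/c2csc3ccccc23)c1` gives 4800 nM. These two numbers lie within the scatter of each other, so compound 2 stands level with compound 1. The next compound, compound 3 `COc1ccc(O)c(C(=O)/C=C/c2csc3ccccc23)c1`, differs from compound 2 as follows: methoxy in place of methyl on an aromatic carbon. This is methoxy in place of methyl on an aromatic carbon, para to a hydroxy group. Among the compounds with values here, only one measured step bears on this change, and only indirectly: a 1.1-fold lower number from compound 1 to compound 2 (0.04 log units; within the scatter), a methyl-for-hydrogen replacement that stays within the scatter. Within the data shown here, no methoxy compound has been measured yet. On that single small step, no shift beyond the scatter is expected in this assay. The expected change is a 1.1-fold lower number from compound 2 to compound 3 (0.06 log units; within the scatter). The estimated value for compound 3 is 4200 nM, with an expected range of 1800 nM to 9500 nM.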

Compound 3, half-maximal inhibitory concentration: 580 nM
Estimate against measurement, compound 3: 7.2-fold (0.86 log units) above, and the stated range ends above it.
By their numbers in this assay, from the lowest: compound 3; then compounds 2 and 1 (each within the scatter of the next).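

In this assay, this aromatic carbon, para to a hydroxy group, proves responsive to the group it carries: methoxy in place of methyl gives an 8.3-fold lower number from compound 2 to compound 3 (0.92 log units; beyond the scatter), whereas methyl in place of hydrogen gave only a 1.1-fold lower number from compound 1 to compound 2 (0.04 log units; within the scatter). Methoxy in place of hydrogen gives a 9.1-fold lower number from compound 1 to compound 3 (0.96 log units; beyond the scatter), so of the two groups shown on this carbon, only methoxy moves the number beyond the scatter. Nothing at hand explains the difference between methoxy and methyl here.

From the compounds shown here alone, it remains open whether this step is particular to methoxy or would also appear with ethoxy, a free hydroxy or a dimethylamino group on the same carbon. Going by these compounds, it is also open whether methoxy on the other carbons of this ring would give a step of similar size.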